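The source may report more compounds than this note shows. Statements on the series, on what has been measured and on what is new or still open speak of the compounds shown alone.

Working notes, measured series, all in a functional assay on SW480 cells (Homo sapiens) for antiproliferative activity, read by MTT assay, with a stated time of 48 h; on this read-out lower numbers stand for stronger inhibition and higher numbers for weaker inhibition:
- compound 1 `CC(=O)OC/C1=C/C[C@](C)(CCC=C(C)C)/C=C/[C@@H](OC(=O)C=C(C)C)[C@](C)(OC(C)=O)/C=C/C1=O`: 3520 nM
- compound 2 `CC(=O)O[C@]1(C)/C=C/C(=O)/C(CO)=C\C[C@](C)(CCC=C(C)C)/C=C/[C@H]1OC(=O)C=C(C)C`: 2010 nM
- compound 3 `CCN(CC)C/C1=C/C[C@](C)(CCC=C(C)C)/C=C/[C@@H](OC(=O)C=C(C)C)[C@](C)(O)/C=C/C1=O`: 270 nM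

Compound 3 has the lowest number of the three, and its gaps to both others lie beyond the scatter. Next is compound 4 `CC(C)=CCC[C@]1(C)/C=C/[C@@H](OC(=O)C=C(C)C)[C@](C)(O)/C=C/C(=O)/C(COC(=O)c2ccc([N+](=O)[O-])cc2)=C\C1`, with this change: ((4-nitrophenyl)carbonyl)oxy in place of diethylamino on a saturated chain carbon bound to a double-bonded ring carbon.

For the measured compounds named here, only one measured step concerns that carbon. a 1.8-fold lower number from compound 1 to compound 2 (0.24 log units; within the scatter) swaps acetyl for hydrogen on the oxygen there, and it stays within the scatter. Compound 4 again has oxygen on that carbon, as do compound 1 and compound 2, and both of those sit well above compound 3 in this assay. However, both also carry an acetyl on another oxygen that compound 3 and compound 4 lack, and no measured step isolates that difference. Going by the values given here, no measured compound carries the aromatic ring either, so the range is kept wide.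

The expected change is a 5.6-fold higher number from compound 3 to compound 4 (0.74 log units; beyond the scatter), a higher number beyond the scatter. Compound 4 is estimated at 1500 nM, with an expected range of 400 nM to 5000 nM.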

Compound 4, half-maximal inhibitory concentration: 570 nM
The estimate for compound 4 lay 2.6-fold (0.42 log units) above the measured number, and the stated range covers the measured number.
By their numbers in this assay, from the lowest: compound 3; then compound 4; then compounds 2 and 1 (each within the scatter of the next).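

In this assay the exchange at this carbon gives a 2.1-fold higher number from compound 3 to compound 4 (0.32 log units; beyond the scatter), a modest step for replacing diethylamino with a much larger group that carries an aromatic ring. The earlier step on this carbon only exchanged acetyl for hydrogen on the oxygen, whereas this one shows that the nitrogen of the diethylamino group is not required for activity, since compound 4 still reads 570 nM with ((4-nitrophenyl)carbonyl)oxy in its place. No measured evidence accounts for the size of this step.

Still open, from the compounds shown here alone, is whether the nitro group or the aromatic ring matters for compound 4, which a plain benzoyl ester on the same carbon would help to separate. Also open, going by these compounds, is how a cyclic amine such as piperidine or morpholine would compare with diethylamino at this position.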